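This account rests on a few compounds, and the source may have more. Where it says the series, first, only, none or still open, it means among the compounds named here.

Measured so far:
compound 1 `Cc1ccc2c(=O)c(CSC(=S)N3CCCCC3)coc2c1` 5100 nM
compound 2 `O=c1cc(CSC(=S)N2CCN(c3ccccc3)CC2)oc2cc(Cl)ccc12` 15900 nM
compound 3 `Cc1ccc2c(=O)c(CSC(=S)N3CCCC3)coc2c1` 3400 nM

In a functional assay on LM7 cells (Homo sapiens) for antiproliferative activity, read by MTT assay, with a stated time of 72 h (a lower number here means a stronger inhibitor, a higher number a weaker inhibitor), compound 1 gives 5100 nM, the second highest of the three numbers. Compound 3 stands nearest, its number lying within the scatter of compound 1, as the step of a 1.5-fold lower number from compound 1 to compound 3 (0.18 log units; within the scatter) shows. Compound 2, the furthest, gives a higher number, beyond the scatter, but it also differs from compound 1 in two places, so its value cannot be assigned to either change.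

Compound 4 `O=c1c(CSC(=S)N2CCCCC2)coc2cc(Cl)ccc12` differs from compound 1 by chloro in place of methyl on an aromatic carbon. Going by the values given here, no measured step changes this position alone, and the one measured step alters the amine on the thiocarbonyl carbon instead. With nothing to support a shift, the number of compound 4 is expected to stay within the scatter of compound 1, with the step of a 1.2-fold higher number from compound 1 to compound 4 (0.07 log units; within the scatter) expected. For compound 4 in this assay the estimate is 6000 nM, ranging from 2500 nM to 15000 nM.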

Compound 4, half-maximal inhibitory concentration: 850 nM
For compound 4 the middle estimate is 7.1-fold (0.85 log units) above the measured one, outside the stated range (below it).
By their numbers in this assay, from the lowest: compound 4; then compounds 3 and 1 (each within the scatter of the next); then compound 2.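

In this assay, chloro in place of methyl on the aromatic carbon gives a 6.0-fold lower number from compound 1 to compound 4 (0.78 log units; beyond the scatter) and so moves the number beyond the scatter. Going by these compounds alone, this shows that this position matters in the assay, which the earlier compounds could not show, since their one step, a 1.5-fold lower number from compound 1 to compound 3 (0.18 log units; within the scatter), changed only the amine on the thiocarbonyl carbon and stayed within the scatter. No measurement here accounts for the difference between chloro and methyl. On these data alone, it remains open whether fluoro, methoxy or a nitrile at this carbon would act like chloro, and whether chloro would give a similar step alongside the pyrrolidin-1-yl group of compound 3.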